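Efficacy of Methylamide Replacing Acid in Phenoxybenzylamine Series

This account rests on a few compounds, and the source may have more. Where it says the series, first, only, none or still open, it means among the compounds named here.

Measured compounds:
Compound 1 `O=C(O)c1ccc(NCc2cccc(Oc3ccccc3)c2)cc1` gives 86% in a functional assay on CHO cells for agonist activity at Free fatty acid receptor 1 (Homo sapiens), read by a luciferase reporter; a higher number here means a larger maximal response, a lower number a smaller maximal response.
Compound 2 `CC(Cc1ccc(NCc2cccc(Oc3ccccc3)c2)cc1)C(=O)O` gives 70% in this assay.
Compound 3 `CC(CC(=O)O)c1ccc(NCc2cccc(Oc3ccccc3)c2)cc1` gives 83% in this assay.

Compound 3 stands second highest of the three numbers. Its nearest neighbour is compound 1, and that gap a number 3 percentage points lower from compound 1 to compound 3 (within the scatter) lies within the scatter, so the two cannot be ordered. Among the measured compounds shown here, the step of a number 13 percentage points higher from compound 2 to compound 3 (beyond the scatter) is modest and beyond the scatter, the only clear separation compound 3 shows.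

Compound 4 `CNC(=O)CCc1ccc(NCc2cccc(Oc3ccccc3)c2)cc1` has not been measured. It differs from compound 3 at one place: 2-(methylcarbamoyl)ethyl in place of 1-(carboxymethyl)ethyl on an aromatic carbon

The three measured steps all exchange one acid-bearing chain for another, so only one of them, the shift in branching a number 13 percentage points higher from compound 2 to compound 3 (beyond the scatter), bears on the present change, and then only in part. For the measured compounds named here, no measured step exchanges the acid itself for an amide, as happens here. Going by the values given here, the steps so far were modest at most, a number 16 percentage points lower from compound 1 to compound 2 (beyond the scatter) being the largest, and compound 4 moves further from the measured set than any of them. On that basis the author expects a downward step a number 18 percentage points lower from compound 3 to compound 4 (beyond the scatter), with wide uncertainty, and estimates compound 4 at 65%, between 35% and 90%.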

Compound 4, largest response reached (reported as percent of maximum), in percent of the reference or control that the assay uses: 67%
Compound 4: the middle estimate sits 2 percentage points below what was measured, and the stated range covers the measured number.
By their numbers in this assay, from the lowest: compounds 4 and 2 (each within the scatter of the next); then compounds 3 and 1 (each within the scatter of the next).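

Compound 4 is the only one of the four that carries no carboxy group, yet in this assay compound 4 gives 67%, so among these compounds a sizeable maximal response does not depend on the acid. On this aromatic carbon, para to a large group, the exchange for 2-(methylcarbamoyl)ethyl still has a cost against two of the acids, with a modest step of a number 16 percentage points lower from compound 3 to compound 4 (beyond the scatter) and another modest step a number 19 percentage points lower from compound 1 to compound 4 (beyond the scatter), whereas the step of a number 3 percentage points lower from compound 2 to compound 4 (within the scatter) leaves the amide chain indistinguishable from the 2-carboxypropyl chain of compound 2. Nothing given here accounts for these differences.

The step from compound 3 changes the branching of the chain as well as the end group, so a straight 2-carboxyethyl chain would be needed to separate the two changes and to show how much of the drop belongs to the amide alone. Going by these compounds, whether the methyl on the amide nitrogen matters also stays open, and a primary amide or an N,N-dimethylamide on the same chain would address it.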